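The source may hold more compounds than are shown below. What is called first, only, known or untested is meant among the compounds shown, and "the series" means these compounds.

Compound 1 `Nc1nc2cc(Cl)c(Cl)cc2n1Cc1ccccc1`: 170000 nM
Compound 2 `Nc1nc2cc(Cl)c(Cl)cc2n1Cc1ccc(F)cc1`: 70000 nM

In a functional assay on KB cells (Homo sapiens) for inhibition (a higher number here means a weaker inhibitor, a lower number a stronger inhibitor), compound 1 has the higher number of the two, which makes it the weaker inhibitor. Compound 3 `CC(C)Nc1nc2cc(Cl)c(Cl)cc2n1Cc1ccccc1` differs from it by isopropyl in place of hydrogen on a nitrogen on an aromatic ring. Among the compounds with values here, no measured step involves that nitrogen. Within the data shown here, the only guide is a 2.4-fold lower number from compound 1 to compound 2 (0.39 log units; beyond the scatter), a modest step made at an aromatic carbon, so it bears on this change only weakly. A similarly modest move to a lower number is expected, with real uncertainty about its direction. The expected change is a 2.8-fold lower number from compound 1 to compound 3 (0.45 log units; beyond the scatter). For compound 3 the estimated value is 60000 nM, within an expected range of 15000 nM to 200000 nM.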

Compound 3, half-maximal inhibitory concentration: 45000 nM
Estimate against measurement, compound 3: 1.3-fold (0.12 log units) above; the range from low to high includes it.
By their numbers in this assay, from the lowest: compounds 3 and 2 (each within the scatter of the next); then compound 1.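

Within the data shown here, the earlier compounds showed a change only at an aromatic carbon, so this is the first look at the amino nitrogen. In this assay, isopropyl in place of hydrogen there gives a 3.8-fold lower number from compound 1 to compound 3 (0.58 log units; beyond the scatter), so inhibition does not depend on this nitrogen keeping that hydrogen, and it strengthens modestly. Nothing measured here explains the change. Still open, as far as these compounds go, is whether a smaller methyl, a longer butyl chain or a carboxylic acid on this nitrogen would move the number further, and how isopropyl and the fluoro group behave together.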